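Aryl variation on the sulfonamide of a shared core

The source may report more compounds than this note shows. Statements on the series, on what has been measured and on what is new or still open speak of the compounds shown alone.

Compound 1 `O=S(=O)(NC1=NCCN1C(=S)SN1CCn2c1nsc2=S)c1ccc(C(F)(F)F)cc1`: in a functional assay on KYSE-510 cells (Homo sapiens) for antiproliferative activity, read by crystal violet staining, with a stated time of 96 h (a lower number here means a stronger inhibitor of growth, a higher number a weaker inhibitor of growth), compound 1 gives >= 20000 nM, which is a limit of the assay.
Compound 2 `O=[N+]([O-])c1ccc(S(=O)(=O)NC2=NCCN2C(=S)SN2CCn3c2nsc3=S)cc1`: compound 2 gives >= 20000 nM, likewise a limit.
Compound 3 `O=S(=O)(NC1=NCCN1C(=S)SN1CCn2c1nsc2=S)c1ccc(Br)cc1`: compound 3 gives >= 20000 nM, again a limit.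

Compound 1 thus stands only at a limit, and all three measured values sit together at that limit (the limit of >= 20000 nM in this assay, at which 3 of the 3 values shown sit). The steps a step that the two limits leave unreadable from compound 1 to compound 2, a step that the two limits leave unreadable from compound 1 to compound 3 and a step that the two limits leave unreadable from compound 2 to compound 3 therefore carry no readable size, and nothing among them separates the three aryl groups. Compound 4 `O=S(=O)(NC1=NCCN1C(=S)SN1CCn2c1nsc2=S)c1ccccc1Cl` carries 2-chlorophenyl in place of 4-(trifluoromethyl)phenyl on a sulfonyl sulfur. Among the compounds with values here, no measured step bears on this change with a readable size, so the step from compound 1 to compound 4 is expected to be a step that the limit leaves unreadable from compound 1 to compound 4, with no direction beyond the scatter. Compound 4 is therefore estimated at 30000 nM, with a range from 8000 nM to 100000 nM, and is expected to return a limit as well.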

Compound 4, concentration for 50% growth inhibition: >= 20000 nM
Compound 4 ended at the assay's limit (the forecaster's own chance of this, stated with the estimate: 85%); the middle value lies beyond the limit too.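

Compound 4 sits at a limit, as do compound 1, compound 2 and compound 3, so no step among them can be read: the limit of >= 20000 nM in this assay, at which 4 of the 4 values shown sit.

On these data alone, whether any aryl group on the shared core gives a readable growth-inhibition value remains open.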